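This account rests on a few compounds, and the source may have more. Where it says the series, first, only, none or still open, it means among the compounds named here.

In a toxicity assay on cells (Erythrocyte, Mus musculus) for activation, read by spectrophotometry and hemolysis, with a stated time of 30 min (a higher number here means that more compound is needed for the effect, a lower number that less compound is needed), compound 1 (`Clc1ccc(/C=N/Nc2nc3ccccc3s2)cc1`) gives > 200 ug/mL as a limit of the assay and not a number. Compound 2 (`CN(C)c1ccc(/C=N/Nc2nc3ccccc3s2)cc1`) gives > 200 ug/mL as a limit too. Neither compound has a number to build on (the limit of > 200 ug/mL in this assay, at which 2 of the 2 values shown sit). Compound 3 (`Clc1ccc(/C=N/Nc2nc3ccccc3s2)c(Cl)c1`) differs from compound 1 by chloro in place of hydrogen on an aromatic carbon and so carries chloro in place of hydrogen on an aromatic carbon, ortho to a large group. For the measured compounds named here, the one measured step (a step that the two limits leave unreadable from compound 1 to compound 2) has no readable size, so no step beyond the scatter is expected in this assay for this change. The expected step is estimated accordingly (a number no higher from compound 1 to compound 3 (the limit leaves the size open)). For compound 3 the expected value is estimated at 200 ug/mL with a range from 100 ug/mL to 400 ug/mL if a number is reported at all.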

Compound 3, half-maximal effective concentration: > 200 ug/mL
Compound 3 gave a limit, no number (the forecaster's own chance of this, stated with the estimate: 85%); the middle value lies on the limit itself.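

Compound 3, like compound 1, gives only a limit and not a number in this assay, so no step between them can be read: the limit of > 200 ug/mL in this assay, at which 3 of the 3 values shown sit.

The compounds shown leave open whether chloro in place of hydrogen on an aromatic carbon changes the concentration needed for the effect.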